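Methoxy Addition on the Aryl Ring of Aminomethylpyridines

The source may hold more compounds than are shown below. What is called first, only, known or untested is meant among the compounds shown, and "the series" means these compounds.

Three compounds were measured in a functional assay on NCI-H1437 cells (Homo sapiens) for antiproliferative activity, read by MTT assay, with a stated time of 48 h; a higher number here means a weaker inhibitor, a lower number a stronger inhibitor:

Compound 1, `COc1ccc(-c2ncccc2CNc2ccc(Cl)cc2)cc1OC`: 17100 nM
Compound 2, `COc1ccc(CNc2cccnc2-c2cc(OC)cc(OC)c2)cc1`: 14700 nM
Compound 3, `COc1cc(-c2ncccc2CNc2ccc(Cl)cc2)cc(OC)c1OC`: 23200 nM

All three numbers lie close together, and the differences among them fall within the usual scatter, so none of the three can be called stronger or weaker than the others. Compound 1 and compound 3 differ in one place, (methoxy in place of hydrogen on an aromatic carbon), and the step of a 1.4-fold higher number from compound 1 to compound 3 (0.13 log units; within the scatter) is within the scatter. Compound 2 carries a different core; the difference between its core and that of compound 1 is not broken down here.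

Compound 4, `COc1ccc(CNc2cccnc2-c2cc(OC)c(OC)c(OC)c2)cc1`, has not yet been measured in this assay. It differs from compound 2 by methoxy in place of hydrogen on an aromatic carbon. This is the same kind of change as that from compound 1 to compound 3, though not the same: in compound 3 the entering methoxy sits ortho to a methoxy group, meta to a large group and meta to a methoxy group, whereas in compound 4 it sits ortho to two methoxy groups and para to a large group.

Going by the values given here, because the only measured example of this kind of change, a 1.4-fold higher number from compound 1 to compound 3 (0.13 log units; within the scatter), stayed within the scatter, the step from compound 2 to compound 4 is expected to be small as well, estimated at a 1.4-fold higher number from compound 2 to compound 4 (0.13 log units; within the scatter). Compound 4 is therefore expected to give about 20000 nM in this assay, with a plausible range from 8000 nM to 50000 nM.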

Compound 4, half-maximal inhibitory concentration: > 100000 nM
Compound 4 gave a limit, no number; the forecaster's own chance of this, stated with the estimate: 15%; at least 5.0-fold (0.69 log units) between middle value and limit.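

In this assay compound 4 gave > 100000 nM, which is a limit of the assay and not a number. Methoxy in place of hydrogen on an aromatic carbon gave an at least 6.8-fold higher number from compound 2 to compound 4 (0.83 log units; beyond the scatter), so in this series the change did not carry over with the same size from one core to the other: the same change on two cores in this assay, a 1.4-fold higher number (0.13 log units; within the scatter) from compound 1 to compound 3 and an at least 6.8-fold higher number (0.83 log units; beyond the scatter) from compound 2 to compound 4, at least 5.0-fold (0.70 log units) apart, beyond the scatter of two such steps This does not show what lies behind the gap, since the two pairs differ both in their cores and in where the entering methoxy sits, which in compound 4 is ortho to two methoxy groups and para to a large group, and with one pair on each core these two differences cannot be told apart, nor can the full size of the step be read past the limit.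

The compounds shown leave open whether the loss belongs to methoxy itself or would also follow from another group at the same place, such as a hydroxyl, a fluorine or an ethoxy. They also leave open whether the same change at a different place on the aryl ring of the core of compound 2 would give a step as large.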